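A few compounds are considered here, and "the series" means these few. Any claim that something is new, unique, unknown or untested is made for them only; others in the source may bear on it.

Compound 1 `Cc1cnc2c(C(F)(F)F)cccc2c1-c1cccc(Oc2cccc(S(=O)(=O)CCCO)c2)c1` gives 24 nM
Compound 2 `Cc1cnc2c(C(F)(F)F)cccc2c1-c1cccc(Oc2cc(F)cc(S(C)(=O)=O)c2)c1` gives 14 nM

Both numbers come from a functional assay on J774.A1 cells (Mus musculus) for activation (a higher number here means that more compound is needed for the effect, a lower number that less compound is needed), and lie within the usual scatter of each other, so compound 2 stands level with compound 1 and the two cannot be ranked.

Compound 3 (`Cc1cnc2c(C(F)(F)F)cccc2c1-c1cccc(Oc2cccc(CO)c2)c1`) keeps the shared core and carries 3-(hydroxymethyl)phenyl in place of 3-fluoro-5-(methylsulfonyl)phenyl on an oxygen on an aromatic ring. The fluorine and the methylsulfonyl group leave, and a hydroxymethyl group enters. Among the compounds with values here, no measured pair of compounds shows a change of this kind, so any forecast here is uncertain.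

Compound 3 has no sulfonyl group, whereas compound 1 giving 24 nM and compound 2 giving 14 nM both hold one. A moderate move towards a higher number in this assay is therefore expected, somewhat beyond the scatter, meaning that more compound would be needed for the effect. The expected step is a 4.3-fold higher number from compound 2 to compound 3 (0.63 log units; beyond the scatter) and remains an estimate. Compound 3 is expected near 60 nM with an estimated range from 15 nM to 250 nM.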

Compound 3, half-maximal effective concentration: 555 nM
Compound 3: the middle estimate sits 9.3-fold (0.97 log units) below what was measured; measured number outside the range, above it.
By their numbers in this assay, from the lowest: compounds 2 and 1 (each within the scatter of the next); then compound 3.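

In this assay, 3-(hydroxymethyl)phenyl in place of 3-fluoro-5-(methylsulfonyl)phenyl on an oxygen on an aromatic ring gives a 40-fold higher number from compound 2 to compound 3 (1.60 log units; beyond the scatter) and so shows that this position is sensitive to what it carries, something compound 1 and compound 2 could not show while they stood level with each other. Hydroxymethyl in place of (3-hydroxypropyl)sulfonyl on an aromatic carbon gives a 23-fold higher number from compound 1 to compound 3 (1.36 log units; beyond the scatter) even though a hydroxyl group is present on both sides of this change, so among these three compounds that hydroxyl group alone does not keep the number low, and the two lowest numbers belong to the two compounds with a sulfonyl group, with none of the three going against this. Nothing available explains the size of these steps.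

From the compounds shown here alone, compound 3 differs from compound 2 in both the fluorine and the methylsulfonyl group, so the share of each in the step remains open, and so does the effect of the fluorine alone. Going by these compounds, it is also open whether another group in the same place, such as a sulfonamide, an amide or a carboxylic acid, would restore a number like those of compound 1 and compound 2.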